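The compounds below may be only part of what the source reports. "The series", "measured", "known", "first", "only" and "open" are said of these compounds alone.

Measured in a functional assay on C8166 cells (Homo sapiens) for cytotoxicity, read by MTT assay (on this read-out higher numbers stand for lower toxicity in this test and lower numbers for higher toxicity in this test), so far:
- Compound 1 `Cc1ccc(C(=O)Nc2cc(Cl)ccc2OCC(=O)Nc2ccc(S(N)(=O)=O)cc2C)c(C)c1` gives 47600 nM
- Compound 2 `Cc1ccc(C)c(C(=O)Nc2cc(Cl)ccc2OCC(=O)Nc2ccc(S(N)(=O)=O)cc2C)c1` gives 79700 nM
- Compound 3 `Cc1ccc(C(=O)Nc2cc(Cl)ccc2OCC(=O)Nc2ccc(S(N)(=O)=O)cc2C)cc1C` gives 84100 nM

Compound 3 cannot be separated from the other two, as both of its steps lie within the scatter (a 1.8-fold higher number from compound 1 to compound 3 (0.25 log units; within the scatter)) and (a 1.1-fold higher number from compound 2 to compound 3 (0.02 log units; within the scatter)). Compound 4 `Cc1cc(S(N)(=O)=O)ccc1NC(=O)COc1ccc(Cl)cc1NC(=O)c1ccc(Cl)c(Cl)c1` carries 3,4-dichlorophenyl in place of 3,4-dimethylphenyl on a carbonyl carbon. For the measured compounds named here, no measured step makes this exchange. Going by the values given here, the only guide is the dimethylphenyl variation around compound 3, which also stayed within the scatter (a 1.7-fold higher number from compound 1 to compound 2 (0.22 log units; within the scatter)). No step beyond the scatter is therefore expected in this assay and the estimated step stays small (a 1.4-fold lower number from compound 3 to compound 4 (0.15 log units; within the scatter)). For compound 4 the expected value is 60000 nM with an estimated range (25000 nM to 130000 nM).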

Compound 4, half-maximal cytotoxic concentration: 158000 nM
Beside the measured number, compound 4's estimate is 2.6-fold (0.42 log units) below it, outside the stated range (above it).
By their numbers in this assay, from the lowest: compounds 1, 2, 3 and 4 (each within the scatter of the next, the first and the last beyond it).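

In this assay, 3,4-dichlorophenyl on a carbonyl carbon is the only exchange shown that puts chlorine in place of methyl, and it stays within the scatter against two dimethylphenyl compounds, with a 1.9-fold higher number from compound 3 to compound 4 (0.27 log units; within the scatter) and a 2.0-fold higher number from compound 2 to compound 4 (0.30 log units; within the scatter). Only against 2,4-dimethylphenyl does a step at this position clear the scatter, a modest one, with a 3.3-fold higher number from compound 1 to compound 4 (0.52 log units; beyond the scatter). Nothing measured here accounts for that step. From the compounds shown here alone, what a phenyl ring carrying a methoxy group or an amine would give on this carbonyl carbon stays open.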